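The source may report more compounds than this note shows. Statements on the series, on what has been measured and on what is new or still open speak of the compounds shown alone.

Measured compounds in this series:

- Compound 1, `COC(=O)c1ccc(NCc2cncn2Cc2ccc(OC)cc2)cc1-c1ccccc1`: "not determined" (no result reported)
- Compound 2, `c1ccc(-c2ccc(Cn3cncc3CNc3ccc(-c4nc5ccccc5o4)c(-c4ccccc4)c3)cc2)cc1`: > 10000 nM
- Compound 3, `COC(=O)c1ccc(NCc2cncn2Cc2ccccc2-c2ccccc2)cc1-c1ccccc1`: "not determined" (no result reported)

In a toxicity assay on NIH3T3 cells (Mus musculus) for cytotoxicity, read by resazurin assay (on this read-out lower numbers stand for an effect already at smaller amounts and higher numbers for an effect only at larger amounts of compound), compound 2 gives > 10000 nM, which is a limit of the assay and not a number. Going by the values given here, compound 2 therefore sits at the limit of > 10000 nM in this assay, at which 1 of the 3 values shown sits; the two remaining entries of the series carry no number at all, so no step between measured compounds can be drawn. For compound 1 this assay gives "not determined" (no result reported) and for compound 3 it gives "not determined" (no result reported).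

The next compound, compound 4, `CCOC(=O)c1ccc(NCc2cncn2Cc2ccc(-c3ccccc3)cc2)cc1-c1ccccc1`, is to be measured in this assay. Compared with compound 2 it carries the change (ethoxycarbonyl in place of 1,3-benzoxazol-2-yl on an aromatic carbon).

Among the compounds with values here, with only one limit in hand and no measured step, the expectation for this change is that compound 4 stays at or beyond the same limit, with no step beyond the usual scatter in either direction. The step from compound 2 to compound 4 is therefore expected to be a step that the limit leaves unreadable from compound 2 to compound 4. In this assay compound 4 is estimated at 15000 nM, within a range from 5000 nM to 50000 nM, with the most likely outcome being that the assay again reports only a limit.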

Compound 4, half-maximal effective concentration: > 10000 nM
Compound 4: no number, only a limit; the forecaster's own chance of this, stated with the estimate: 70%; the middle value is on the limit's open side.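

In this assay compound 4 gives > 10000 nM, which is a limit of the assay and not a number. Compound 2 also stands at a limit, so no step can be read between compound 2 and compound 4. The compounds shown leave open whether ethoxycarbonyl in place of 1,3-benzoxazol-2-yl changes the half-maximal effective concentration in this assay at all.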